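Ester-to-acid and methoxy-to-hydroxy changes under cytotoxicity testing

This account rests on a few compounds, and the source may have more. Where it says the series, first, only, none or still open, it means among the compounds named here.

Measured so far:
compound 1 `CNC(=O)c1cc(Oc2ccc3c(C)c(C(=O)OC)sc3c2)ccn1`, 15700 nM
compound 2 `CNC(=O)c1cc(Oc2ccc3c(C)c(C(=O)O)sc3c2)ccn1`, > 100000 nM
compound 3 `CCOC(=O)c1sc2cc(OC)ccc2c1C`, > 100000 nM

In an ADME assay on HeLa cells (Homo sapiens) for cytotoxicity, read by MTT assay, with a stated time of 2 days (a higher number here means that more compound is tolerated, a lower number that less compound is tolerated), compound 1 gives 15700 nM. For compound 2 the assay reports only a limit, > 100000 nM. The change between them, (hydrogen in place of methyl on an oxygen next to a carbonyl group), makes the step of an at least 6.3-fold higher number from compound 1 to compound 2 (0.80 log units; beyond the scatter); its size is bounded by the limit of > 100000 nM in this assay, at which 2 of the 3 values shown sit. The difference between the core of compound 1 and the core of compound 3 is not broken down here. For compound 3 the value is also a limit, > 100000 nM. Compound 4 `CCOC(=O)c1sc2cc(O)ccc2c1C` is the unmeasured one; the change hydrogen in place of methyl on an oxygen on an aromatic ring is the same kind of change as before, but here the oxygen sits on an aromatic ring rather than next to a carbonyl group. Because compound 3 already stands at the limit of > 100000 nM in this assay, at which 2 of the 3 values shown sit, compound 4 is expected to stay near that limit, an expected step of a number no higher from compound 3 to compound 4 (the limit leaves the size open). The estimate for compound 4 is 100000 nM, between 40000 nM and 250000 nM.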

Compound 4, half-maximal cytotoxic concentration: 46600 nM
For compound 4 the middle estimate is 2.1-fold (0.33 log units) above the measured one, within the range that was stated.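

In this assay, hydrogen in place of methyl on an oxygen on an aromatic ring gives an at least 2.1-fold lower number from compound 3 to compound 4 (0.33 log units; beyond the scatter). Set beside the earlier step, hydrogen in place of methyl does not carry over from one core to the other, and the two steps run in opposite directions: the same change on two cores in this assay, an at least 6.3-fold higher number (0.80 log units; beyond the scatter) from compound 1 to compound 2 and an at least 2.1-fold lower number (0.33 log units; beyond the scatter) from compound 3 to compound 4, at least 13-fold (1.13 log units) apart, beyond the scatter of two such steps The two pairs do not separate the effect of the core from that of the place of the oxygen, and the steps have no settled size, with compound 2 and compound 3 each at a limit: the limit of > 100000 nM in this assay, at which 2 of the 4 values shown sit.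

The compounds shown leave open how an amine or a longer chain on that oxygen would read in this assay. They also leave open whether methoxy to hydroxy would give the same result on the core of compound 1.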